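Compound 3: replacing methyl with hydroxy

A few compounds are considered here, and "the series" means these few. Any claim that something is new, unique, unknown or untested is made for them only; others in the source may bear on it.

In a physicochemical assay for lipophilicity, at pH 7.4 (a higher number here means a more lipophilic compound, a lower number a more polar compound), compound 1 (`COc1cccc(C(=O)NCc2c(C)cc(C)[nH]c2=O)c1F`) gives 1.4 and compound 2 (`COc1cccc(C(=O)NCc2c(C)cc(C)[nH]c2=O)c1C`) gives 1.5. Among the compounds with values here, compound 2 therefore stands within the scatter of compound 1, the only other measured compound.

The next structure is compound 3 (`COc1cccc(C(=O)NCc2c(C)cc(C)[nH]c2=O)c1O`), and the change is hydroxy in place of methyl on an aromatic carbon, ortho to a large group and ortho to a methoxy group.

Within the data shown here, one measured step bears on this, at the same place on the ring: a number 0.10 log units higher from compound 1 to compound 2 (within the scatter), with methyl in place of fluoro. That step does not separate the two groups in this assay, and it does not involve hydroxy, so the data hold no direct measure of this change. The expectation rests on the structural change alone, starting from compound 2 at 1.5, and a moderately lower number is expected in this assay. The expected step is a number 0.40 log units lower from compound 2 to compound 3 (beyond the scatter). The estimate for compound 3 is 1.1, with an expected range from 0.6 to 1.6.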

Compound 3, distribution coefficient: 1.9
Compound 3: middle estimate off by 0.80 log units, on the low side; measured number above the stated range.
By their numbers in this assay, from the lowest: compounds 1 and 2 (each within the scatter of the next); then compound 3.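

In this assay, hydroxy on this aromatic carbon, ortho to a large group and ortho to a methoxy group, separates from both earlier groups, with a number 0.40 log units higher from compound 2 to compound 3 (beyond the scatter) where it replaces methyl and a number 0.50 log units higher from compound 1 to compound 3 (beyond the scatter) where it replaces fluoro. Fluoro and methyl alone gave no separation at this position, so compound 3 is the first of the series to stand apart from the others, and it does so on the high side of the scale even though hydroxy brings in a hydrogen-bond donor and acceptor that neither earlier group carries. Nothing available explains the direction of this step.

From the compounds shown here alone, it remains open whether an amine or a carboxylic acid on the same aromatic carbon would also give a number above those of compound 1 and compound 2, or whether the rise belongs to hydroxy alone. Going by these compounds, all three compounds carry the methoxy group on the neighbouring position named above, so whether the step holds with an ethoxy group there, or with no such group, also remains open.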